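A few compounds are considered here, and "the series" means these few. Any claim that something is new, unique, unknown or untested is made for them only; others in the source may bear on it.

Compound 3 `CCCCCc1ccc(Nc2cccc3c2C(=O)N(C2CCC(=O)NC2=O)C3=O)cc1` gives 23% in an assay on FRT-Jurkat cells for inhibition of nuclear factor NF-kappa-B complex (Homo sapiens), read by flow cytometry, with a stated time of 24 h, tested at 10 uM (on this read-out lower numbers stand for less inhibition and higher numbers for more inhibition at the one concentration tested (going by the name of the read-out)), which places it at the top of the three numbers recorded, although only the gap to compound 1 lies beyond the scatter. Compound 2 `COc1ccc(Nc2cccc3c2C(=O)N(C2CCC(=O)NC2=O)C3=O)cc1` gives 13%, and compound 1 `O=C1CCC(N2C(=O)c3cccc(Nc4ccccn4)c3C2=O)C(=O)N1` gives 1%. The change from pyridin-2-yl to 4-methoxyphenyl brought a number 12 percentage points higher from compound 1 to compound 2 (beyond the scatter), whereas the exchange of methoxy for pentyl brought a number 10 percentage points higher from compound 2 to compound 3 (within the scatter).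

Compound 4 `CCc1ccc(Nc2cccc3c2C(=O)N(C2CCC(=O)NC2=O)C3=O)cc1` differs from compound 3 by hydrogen in place of propyl on a saturated chain carbon, two bonds along the chain from an aromatic carbon. Among the measured compounds shown here, the only measured step that bears on a change of this sort is the one from compound 2 to compound 3, where a whole pentyl chain replaced methoxy and yet the number moved within the scatter. Cutting the pentyl back to ethyl is a smaller change still, so no step beyond the scatter is expected in this assay. For compound 4 the expected number is 17%, with a range from 6% to 28%, which would mean an estimated a number 6 percentage points lower from compound 3 to compound 4 (within the scatter).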

Compound 4, a percentage reported as inhibition, at one concentration (the size of the read-out at that concentration, not a potency): 17%
Beside the measured number, compound 4's estimate shows no gap at the digits printed, and the stated range covers the measured number.
By their numbers in this assay, from the lowest: compound 1; then compounds 2, 4 and 3 (each within the scatter of the next).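

Cutting the pentyl back to ethyl gives a number 6 percentage points lower from compound 3 to compound 4 (within the scatter) in this assay and so leaves the number unresolved between these two chain lengths. Ethyl in place of methoxy gives a number 4 percentage points higher from compound 2 to compound 4 (within the scatter) as well, which means that compounds 2, 3 and 4 cannot be put in order on this read-out. The replacement of pyridin-2-yl by 4-ethylphenyl gives a number 16 percentage points higher from compound 1 to compound 4 (beyond the scatter) and is the second change of this kind beyond the scatter, after a number 12 percentage points higher from compound 1 to compound 2 (beyond the scatter) with 4-methoxyphenyl, so the separation of compound 1 from its neighbours does not rest on the methoxy group alone.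

Going by these compounds, whether methyl, a chain longer than pentyl, or an amine or carboxylic acid at the end of the chain would move the number beyond the scatter stays open. No evidence given here accounts for any of these steps.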